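From 2-fluorobenzyl to 2-methylbenzyl on a shared core

The compounds below may be only part of what the source reports. "The series", "measured", "known", "first", "only" and "open" are said of these compounds alone.

Among the measured compounds shown here, in a functional assay on A-375 cells (Homo sapiens) for antiproliferative activity, read by MTT assay, with a stated time of 24 h (on this read-out higher numbers stand for weaker inhibition and lower numbers for stronger inhibition), compound 1 `C#CCOc1ccc2c(=O)c(-c3cc(OC)c(OC)cc3OC)coc2c1` gives 3680 nM and compound 2 `COc1cc(OC)c(-c2coc3cc(OCc4ccccc4F)ccc3c2=O)cc1OC` gives 2100 nM, which places compound 2 within the scatter of the only other measured compound. Compound 3 `COc1cc(OC)c(-c2coc3cc(OCc4ccccc4C)ccc3c2=O)cc1OC` carries methyl in place of fluoro on an aromatic carbon, ortho to a large group (methyl in place of fluoro on an aromatic carbon). For the measured compounds named here, the only measured step, a 1.8-fold lower number from compound 1 to compound 2 (0.24 log units; within the scatter), lies within the scatter and involves no such exchange, so no step beyond the scatter is expected in this assay. The expected change is a 1.1-fold higher number from compound 2 to compound 3 (0.04 log units; within the scatter). For compound 3 the estimated value is 2300 nM, with an expected range of 900 nM to 5500 nM.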

Compound 3, half-maximal inhibitory concentration: 1360 nM
Compound 3: the middle estimate sits 1.7-fold (0.23 log units) above what was measured; the range from low to high includes it.
By their numbers in this assay, from the lowest: compounds 3, 2 and 1 (each within the scatter of the next, the first and the last beyond it).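

In this assay, methyl in place of fluoro gives a 1.5-fold lower number from compound 2 to compound 3 (0.19 log units; within the scatter) and so cannot be told apart from no change at this place on the ring. Among the compounds shown here, only the wider exchange of ethynyl for 2-methylphenyl on the ether chain gives a step beyond the scatter, though a modest one: a 2.7-fold lower number from compound 1 to compound 3 (0.43 log units; beyond the scatter) is the first such step. Nothing measured here accounts for either step. Going by these compounds, what an amine or a carboxylic acid would do on this same aromatic carbon remains open.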